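This account rests on a few compounds, and the source may have more. Where it says the series, first, only, none or still open, it means among the compounds named here.

Measured compounds:
Compound 1, `COC(=O)c1ccc(NCc2cncn2Cc2ccccc2)cc1-c1ccccc1`, in a toxicity assay on NIH3T3 cells (Mus musculus) for cytotoxicity, read by resazurin assay; on this read-out higher numbers stand for an effect only at larger amounts of compound and lower numbers for an effect already at smaller amounts: > 1000 nM.
Compound 2, `CC(C)c1ccc(Cn2cncc2CNc2ccc(-c3nc4ccccc4s3)c(-c3ccccc3)c2)cc1`: > 1000 nM.
Compound 3, `c1ccc(Cn2cncc2CNc2cccc(-c3ccccc3)c2)cc1`: > 750 nM.

Each of these three values is a limit of this assay and not a number. Compound 1 therefore stands only at a limit, and it cannot be ranked against compound 2 or compound 3, which also sit at limits.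

Compound 4, `COC(=O)c1ccc(NCc2cncn2Cc2ccc(Br)cc2)cc1-c1ccccc1`, differs from compound 1 by bromo in place of hydrogen on an aromatic carbon. For the measured compounds named here, only one measured step changes a single place, a step that the two limits leave unreadable from compound 1 to compound 3, and its size cannot be read because compound 1 sits at the limit of > 1000 nM in this assay, at which 2 of the 3 values shown sit, while compound 3 sits at the limit of > 750 nM in this assay, at which 1 of the 3 values shown sits. Going by the values given here, that step also concerns a different place, and no measured step touches the benzyl at all. So no measured step bears on this change, and nothing here points to an effect beyond the scatter in either direction.

I expect compound 4 to give 1500 nM, with a range from 700 nM to 5000 nM, most likely reported again as a limit. This estimate means a step that the limit leaves unreadable from compound 1 to compound 4.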

Compound 4, half-maximal effective concentration: > 10000 nM
Compound 4: a limit, no number; the forecaster's own chance of this, stated with the estimate: 80%; at least 6.6-fold (0.82 log units) between middle value and limit.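

In this assay compound 4 gives > 10000 nM, which is a limit and not a number. For the compounds shown here, compound 1 also stands at a limit, so no step between compound 1 and compound 4 can be read. The compounds shown leave open whether 4-bromobenzyl in place of benzyl changes the effect on these cells, and at what amount any of the four compounds acts.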